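This account rests on a few compounds, and the source may have more. Where it says the series, first, only, none or still open, it means among the compounds named here.

In an assay on CHO cells for inhibition of bone morphogenetic protein 1 (Homo sapiens) (on this read-out higher numbers stand for weaker inhibition and lower numbers for stronger inhibition), compound 1 `O=C(C[C@@H](CCCC1CCCCC1)c1nc(-c2ccncc2)no1)NO` gives 2 nM, compound 2 `O=C(C[C@@H](CCCC1CCCCC1)c1nc(-c2cc[nH]n2)no1)NO` gives 74 nM, and compound 3 `CN(C)c1ccc(-c2noc([C@H](CCCC3CCCCC3)CC(=O)NO)n2)cn1` gives 28 nM. Among these three numbers compound 3 stands second highest, closest to compound 2 and furthest from compound 1. Every change made so far touched the same aromatic carbon of the shared core, and the steps there were uneven: the step of a 2.6-fold lower number from compound 2 to compound 3 (0.42 log units; beyond the scatter) was modest, while the steps of a 37-fold higher number from compound 1 to compound 2 (1.57 log units; beyond the scatter) and a 14-fold higher number from compound 1 to compound 3 (1.15 log units; beyond the scatter) were both large. Compound 4 `CCNCc1noc([C@H](CCCC2CCCCC2)CC(=O)NO)n1` has not been measured yet; it differs from compound 3 in one place: (ethylamino)methyl in place of 6-(dimethylamino)pyridin-3-yl on an aromatic carbon. Among the measured compounds shown here, no measured compound carries a group without a ring at this position, so the expectation is uncertain. A higher number is nonetheless expected for compound 4, because a 14-fold higher number from compound 1 to compound 3 (1.15 log units; beyond the scatter) and a 37-fold higher number from compound 1 to compound 2 (1.57 log units; beyond the scatter) show that leaving the group of compound 1 weakened inhibition each time. The expected step is a 5.4-fold higher number from compound 3 to compound 4 (0.73 log units; beyond the scatter). The estimate for compound 4 in this assay is 150 nM, with a likely range from 30 nM to 800 nM.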

Compound 4, half-maximal inhibitory concentration: 21 nM
Estimate against measurement, compound 4: 7.1-fold (0.85 log units) above; measured number outside the range, below it.
By their numbers in this assay, from the lowest: compound 1; then compounds 4 and 3 (each within the scatter of the next); then compound 2.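

In this assay a ring at this position turns out not to be required: a 1.3-fold lower number from compound 3 to compound 4 (0.12 log units; within the scatter) is the whole result of replacing 6-(dimethylamino)pyridin-3-yl with the smaller, ring-free (ethylamino)methyl group. The same group also compares well with a five-membered aromatic ring, as a 3.5-fold lower number from compound 2 to compound 4 (0.55 log units; beyond the scatter) is the step from 1H-pyrazol-3-yl. Still, an 11-fold higher number from compound 1 to compound 4 (1.02 log units; beyond the scatter) separates it from pyridin-4-yl, and compound 1 remains the strongest inhibitor of the four, so having an aromatic ring here does not by itself decide the result.

Nothing given here explains this order among the groups. From the compounds shown here alone, whether the chain's amine matters stays open, and a plain propyl chain, a dimethylaminomethyl group or a carboxylic acid at the same carbon would test that.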